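Methyl-to-hydrogen step on a pyrazolopyrimidine core

The compounds below may be only part of what the source reports. "The series", "measured", "known", "first", "only" and "open" are said of these compounds alone.

Of the compounds shown here, three sharing a bicyclic core have been measured in an assay for inhibition of Indoleamine 2,3-dioxygenase 1 (Homo sapiens), read by spectrophotometry, with a stated time of 180 min, tested at 10 uM; a lower number here means a weaker effect, a higher number a stronger effect of the compound at the concentration tested. Compound 1 `Cc1nc(NCc2cccc(C(=O)O)c2)c2cn[nH]c2n1` gives 5%. Compound 3 `Cc1ccc(CNc2cc(Br)cc3[nH]ncc23)cc1` gives 20%, and compound 2 `Brc1cc(NCc2ccccc2)c2cn[nH]c2c1` gives 37%. Compound 1 thus has the lowest of the three numbers; the difference between the core of compound 1 and the core of compound 3 is not broken down here.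

From compound 3 to compound 2 the change is hydrogen in place of methyl on an aromatic carbon, and it made a step of a number 17 percentage points higher from compound 3 to compound 2 (beyond the scatter). The unmeasured compound 4 `O=C(O)c1cccc(CNc2ncnc3[nH]ncc23)c1` is reached from compound 1 by hydrogen in place of methyl on an aromatic carbon. This is the same kind of change, not the same: in compound 3 the methyl sits on an aromatic carbon of a six-membered aromatic ring of carbon only, para to a large group, whereas in compound 1 it sits on a six-membered aromatic ring with 2 nitrogen, part of a fused system of two rings, between two ring nitrogen atoms.

Among the compounds with values here, because compound 2 reached 37% from compound 3, a gain of a similar size is expected from compound 1 to compound 4, namely a number 10 percentage points higher from compound 1 to compound 4 (within the scatter), though the different place and the single precedent leave this uncertain. Compound 4 is therefore estimated at 15%, between 0% and 32%.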

Compound 4, a percentage reported as inhibition, at one concentration (the size of the read-out at that concentration, not a potency): 2%
For compound 4 the middle estimate is 13 percentage points above the measured one, within the range that was stated.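

In this assay, compound 1 gives 5% and compound 4 gives 2%, and putting hydrogen in place of the methyl between two ring nitrogen atoms makes a step of a number 3 percentage points lower from compound 1 to compound 4 (within the scatter), so on this core the change has no effect that can be told from the scatter. Set beside the earlier pair, the same kind of change did not carry over from one core to the other: the same change on two cores in this assay, a number 17 percentage points higher (beyond the scatter) from compound 3 to compound 2 and a number 3 percentage points lower (within the scatter) from compound 1 to compound 4, 20 percentage points apart, beyond the scatter of two such steps. This shows that the step seen on the core of compound 3 cannot be assumed for the core of compound 1, but it rests on a single pair per core, with the methyl in a different place in each pair, and it does not show which of the differences between the two pairs separates their steps or how the change would behave on any further core.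

The compounds shown leave open whether an amine or a longer chain in place of the methyl on the core of compound 1 would give a number beyond the scatter from that of compound 1. They also leave open whether a nitrile or an amide in place of the carboxylic acid of compound 4 would change its number.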